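The source may report more compounds than this note shows. Statements on the series, on what has been measured and on what is new or still open speak of the compounds shown alone.

Compound 1, `O=C1/C(=C/c2ccccc2F)CN(S(=O)(=O)c2ccc(F)cc2)C/C1=C\c1ccccc1F`: 8500 nM
Compound 2, `CC(=O)Nc1ccc(S(=O)(=O)N2C/C(=C\c3ccccc3F)C(=O)/C(=C/c3ccccc3F)C2)cc1`: 5500 nM

Both compounds were tested in a functional assay on QGY-7703 cells (Homo sapiens) for cytotoxicity, read by MTT assay, with a stated time of 24 h; a higher number here means a weaker inhibitor, a lower number a stronger inhibitor. Compound 2 holds the lowest of the two numbers, but its nearest neighbour is compound 1, and the step of a 1.5-fold lower number from compound 1 to compound 2 (0.19 log units; within the scatter) falls within the scatter, so the two cannot be ordered with confidence.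

Compound 3, `COc1cc(/C=C2\CN(S(=O)(=O)c3ccc(NC(C)=O)cc3)C/C(=C\c3ccccc3F)C2=O)cc(OC)c1OC`, has not yet been measured. It differs from compound 2 in one place: 3,4,5-trimethoxyphenyl in place of 2-fluorophenyl on a double-bonded chain carbon bound to a double-bonded ring carbon. Among the measured compounds shown here, no measured step touches this place; the only step available, a 1.5-fold lower number from compound 1 to compound 2 (0.19 log units; within the scatter), concerns a different part of the shared core and itself stayed within the scatter, so it offers little guidance about the new change. With nothing to anchor a direction, the expected step is modest, a 1.4-fold lower number from compound 2 to compound 3 (0.14 log units; within the scatter), carrying wide uncertainty. Compound 3 is estimated at 4000 nM, with a range from 1500 nM to 12000 nM.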

Compound 3, half-maximal inhibitory concentration: 2680 nM
Compound 3: the middle estimate sits 1.5-fold (0.17 log units) above what was measured; measured number inside the range.
By their numbers in this assay, from the lowest: compound 3; then compounds 2 and 1 (each within the scatter of the next).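

At the place on a double-bonded chain carbon bound to a double-bonded ring carbon, 3,4,5-trimethoxyphenyl in place of 2-fluorophenyl gives the only step among these compounds in this assay that lies beyond the scatter (a 2.1-fold lower number from compound 2 to compound 3 (0.31 log units; beyond the scatter)), though it is modest. The position therefore accepts the larger group, with its 12 heavy atoms and 3 hydrogen-bond acceptors, without the number rising. Nothing available accounts for this step.

The compounds shown leave open whether the step comes from the three methoxy groups together or from the loss of the 2-fluorophenyl group, and how a single methoxy group, an amine or a carboxylic acid on that ring would compare. They also leave open whether the same exchange at the remaining 2-fluorophenyl group would move the number further.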